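Swapping Fluoro for Sulfamoyl on the Aniline Ring

The compounds below may be only part of what the source reports. "The series", "measured", "known", "first", "only" and "open" are said of these compounds alone.

Measured compounds:
- compound 1, `Cc1cc(C)cc(Nc2nccc(-c3ccccn3)n2)c1`: 100 nM
- compound 2, `Nc1cccc(Nc2nccc(-c3ccccn3)n2)c1`: 300 nM
- compound 3, `Fc1ccc(Nc2nccc(-c3ccncc3)n2)cc1`: 1900 nM

All three compounds were tested in a functional assay for inhibition, with Homo sapiens as the target; a lower number here means a stronger inhibitor, a higher number a weaker inhibitor. Among them, compound 3 stands at the high end: its number is the largest of the three, and its gap to compound 2 and to compound 1 lies beyond the usual scatter, so compound 3 is the weakest inhibitor of this set.

The next compound, compound 4, `NS(=O)(=O)c1ccc(Nc2nccc(-c3ccncc3)n2)cc1`, has not been measured. It differs from compound 3 in one place: sulfamoyl in place of fluoro on an aromatic carbon. Within the data shown here, no pair of measured compounds shows this particular change, so its effect in this assay cannot be read off directly.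

Still, a moderate improvement is expected for compound 4, since compound 2, which also carries a hydrogen-bond donor on that ring, gives 300 nM, a stronger result than compound 3. The step from compound 3 to compound 4 is therefore expected to be a 2.7-fold lower number from compound 3 to compound 4 (0.43 log units; beyond the scatter). Compound 4 is estimated to give 700 nM in this assay, with a range of 150 nM to 3500 nM.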

Compound 4, half-maximal inhibitory concentration: 5100 nM
Compound 4: the middle estimate sits 7.3-fold (0.86 log units) below what was measured; measured number above the stated range.
By their numbers in this assay, from the lowest: compound 1; then compound 2; then compound 3; then compound 4.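

Among these compounds, this is the first change in a single place. In this assay, putting sulfamoyl in place of fluoro on the aromatic carbon para to a large group gives a modest loss of inhibition that lies beyond the scatter (a 2.7-fold higher number from compound 3 to compound 4 (0.43 log units; beyond the scatter)). At this position, then, the larger group, which brings a hydrogen-bond donor and hydrogen-bond acceptors that fluoro lacks, gives no gain, and nothing in the data explains the loss.

Still open, on these data alone, is whether a carboxylic acid or a methoxy group at this same place would stay close to fluoro or fall further, which would help separate the effect of size from that of the particular group. Also open, as far as these compounds go, is whether the same swap would weaken inhibition on the core of compound 1.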